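From 2-Fluorophenyl to 4-Bromophenyl on a Shared Core

The source may hold more compounds than are shown below. What is called first, only, known or untested is meant among the compounds shown, and "the series" means these compounds.

Compound 1 `O=C(/C=C/c1ccc2c(c1)B(O)OC2)c1ccc(O)cc1` and compound 2 `O=C(/C=C/c1ccc2c(c1)B(O)OC2)c1ccccc1F` share a core and differ only in the group on a carbonyl carbon. Both were measured in an ADME assay on L929 cells (Mus musculus) for cytotoxicity, read by resazurin assay, with a stated time of 72 h; a higher number here means a weaker inhibitor, a lower number a stronger inhibitor. Compound 1 gives > 10 ug/mL, which is a limit of the assay and not a number. Compound 2 gives > 10 ug/mL, which is again a limit and not a number. The two results therefore stand together at the limit of > 10 ug/mL in this assay, at which 2 of the 2 values shown sit, and compound 2 has no exact position of its own.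

Compound 3 `O=C(/C=C/c1ccc2c(c1)B(O)OC2)c1ccc(Br)cc1` keeps the same core, and the structural change is 4-bromophenyl in place of 2-fluorophenyl on a carbonyl carbon. Within the data shown here, the only measured step bearing on this change is a step that the two limits leave unreadable from compound 1 to compound 2. Because of a step that the two limits leave unreadable from compound 1 to compound 2 no step size carries over to the new change, so no step beyond the scatter is expected in this assay, and no direction can be named. The estimated step is a step that the limit leaves unreadable from compound 2 to compound 3. For compound 3 the expected value is 15 ug/mL, with an estimated range from 7 ug/mL to 40 ug/mL.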

Compound 3, half-maximal inhibitory concentration: > 10 ug/mL
Compound 3 gave a limit, no number; the forecaster's own chance of this, stated with the estimate: 75%; the middle value lies beyond the limit too.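

In this assay compound 3 also gives a limit and not a number, so no step can be read from compound 2 to compound 3 or from compound 1 to compound 3: the limit of > 10 ug/mL in this assay, at which 3 of the 3 values shown sit.

The compounds shown leave open where compounds 1, 2 and 3 truly lie, and whether 4-hydroxyphenyl, 2-fluorophenyl and 4-bromophenyl on the carbonyl carbon differ at all in cytotoxicity.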